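The source may hold more compounds than are shown below. What is called first, only, known or untested is meant among the compounds shown, and "the series" means these compounds.

Compound 1, `C[C@H](NC(=O)c1c(C(F)(F)F)nnn1Cc1ccc(C(F)(F)F)cc1)c1ccc(C(=O)O)cc1`: 225 nM
Compound 2, `C[C@H](NC(=O)c1cnnn1Cc1ccc(C(F)(F)F)cc1)c1ccc(C(=O)O)cc1`: > 10000 nM (a limit of the assay)
Compound 3, `C[C@H](NC(=O)c1c(C2CC2)nnn1Cc1ccc(C(F)(F)F)cc1)c1ccc(C(=O)O)cc1`: 52.1 nM

In a functional assay on CHO cells for antagonist activity at prostaglandin E2 receptor EP4 subtype (Homo sapiens), read by calcium flux, with a stated time of 15 min (on this read-out lower numbers stand for stronger inhibition and higher numbers for weaker inhibition), compound 3 gives 52.1 nM, the lowest of the two numbers reported; the nearest is compound 1, which gives 225 nM. For compound 2 this assay reports only a limit, > 10000 nM. Compound 2 thus stands at the limit of > 10000 nM in this assay, at which 1 of the 3 values shown sits.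

Compound 4, `C[C@H](NC(=O)c1c(C2CCCC2)nnn1Cc1ccc(C(F)(F)F)cc1)c1ccc(C(=O)O)cc1`, differs from compound 3 in one place: cyclopentyl in place of cyclopropyl on an aromatic carbon. All three measured steps concern the same aromatic carbon. The step of an at least 44-fold higher number from compound 1 to compound 2 (1.64 log units; beyond the scatter) (hydrogen in place of trifluoromethyl) is large, the step of a 4.3-fold lower number from compound 1 to compound 3 (0.64 log units; beyond the scatter) (cyclopropyl in place of trifluoromethyl) is modest, and the step of an at least 190-fold lower number from compound 2 to compound 3 (2.28 log units; beyond the scatter) (cyclopropyl in place of hydrogen) is large. The two steps leading toward compound 3 both run to lower numbers as the group at this carbon grows, but none of them reaches a group as large as cyclopentyl, so the present step carries more uncertainty. The expectation for compound 4 is no step beyond the scatter, with a modest change in either direction remaining possible. Compound 4 is therefore expected at 60 nM, with a range from 15 nM to 250 nM. This estimate corresponds to a 1.2-fold higher number from compound 3 to compound 4 (0.06 log units; within the scatter).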

Compound 4, half-maximal inhibitory concentration: 65.1 nM
Compound 4: the middle estimate sits 1.1-fold (0.04 log units) below what was measured; low and high end bracket the measured number.
By their numbers in this assay, from the lowest: compounds 3 and 4 (each within the scatter of the next); then compound 1. At a limit, above all of these: compound 2.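

In this assay, among these compounds, cyclopentyl in place of cyclopropyl on this aromatic carbon gives a 1.2-fold higher number from compound 3 to compound 4 (0.10 log units; within the scatter), which shows that the position accepts a ring larger than any group carried by the earlier compounds without a step beyond the scatter. The advantage over trifluoromethyl also survives this larger ring, with a 3.5-fold lower number from compound 1 to compound 4 (0.54 log units; beyond the scatter), so among the compounds shown it is not confined to cyclopropyl. The contrast with hydrogen remains large, with an at least 150-fold lower number from compound 2 to compound 4 (2.18 log units; beyond the scatter), but that step rests on a value that is a limit of the assay: the limit of > 10000 nM in this assay, at which 1 of the 4 values shown sits.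

The compounds shown leave open how far this acceptance of size extends, for instance to cyclohexyl, to a phenyl ring or to a longer chain such as n-butyl. They also leave open whether open-chain branched groups such as isopropyl or tert-butyl, or a ring carrying an amine or a hydroxyl group, would fall with compound 3 and compound 4 or nearer to compound 1.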